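This account rests on a few compounds, and the source may have more. Where it says the series, first, only, none or still open, it means among the compounds named here.

Cytotoxicity across this set is followed in an ADME assay on HEp-2 cells (Homo sapiens) for cytotoxicity, read by CCK-8 assay, with a stated time of 5 days; a lower number here means that less compound is tolerated, a higher number that more compound is tolerated. Compound 1, `NCCCNc1cc(N2CCc3ccccc3C2)nc2ccccc12`, gives 8400 nM in this assay. Compound 2, `NCC(O)CNc1cc(N2Cc3ccccc3C2)nc2ccccc12`, gives 2900 nM in this assay. Among the measured compounds shown here, compound 3, `Cc1ccc2nc(N3CCCc4ccc(F)cc4C3)cc(NCCN(C)C)c2c1`, gives 89000 nM in this assay, the highest number of the three; the nearest of the other two numbers belongs to compound 1 and the furthest to compound 2, and both gaps lie beyond the usual scatter, so compound 3 is the best tolerated compound measured so far.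

The next compound in the series is compound 4, `CC(=O)NCCNc1cc(N2CCCc3ccc(F)cc3C2)nc2ccc(C)cc12`, which is still to be measured in this assay. Relative to compound 3 it carries a single change: acetamido in place of dimethylamino on a saturated chain carbon, two bonds along the chain from a nitrogen on an aromatic ring. For the measured compounds named here, no pair of measured compounds in the set differs in one place, so there is no measured step of this kind to lean on, and the reading of compound 3 is the only direct anchor.

Given that anchor, the step from compound 3 to compound 4 in this assay is expected to be small, most likely no further than the scatter, with a slight lean toward a higher number: a 1.2-fold higher number from compound 3 to compound 4 (0.09 log units; within the scatter). Compound 4 is therefore estimated at 110000 nM in this assay, within a range of 35000 nM to 300000 nM.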

Compound 4, half-maximal cytotoxic concentration: 66000 nM
Compound 4: middle estimate off by 1.7-fold (0.22 log units), on the high side; the range from low to high includes it.
By their numbers in this assay, from the lowest: compound 2; then compound 1; then compounds 4 and 3 (each within the scatter of the next).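

In this assay, among the compounds shown here, this pair gives the first direct reading at this position: a 1.3-fold lower number from compound 3 to compound 4 (0.13 log units; within the scatter), so compounds 3 and 4 cannot be told apart here. Acetamido, with its added carbonyl and hydrogen-bond donor, therefore sits on the saturated chain carbon, two bonds along the chain from a nitrogen on an aromatic ring, with no change beyond the scatter from the dimethylamino group; within this pair, the high number does not depend on keeping dimethylamino. No measurement in hand explains this outcome.

For the compounds shown here, whether the same holds for a carboxylic acid, a morpholine or a longer chain in this place remains open, since dimethylamino and acetamido are the only two groups compared on this core. Compounds 1 and 2 differ from compounds 3 and 4 in more than one place, so their lower numbers cannot be assigned to any single part, and the pair does not show whether the same change would behave alike on the cores of compounds 1 and 2.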